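Swapping Fluoro for Chloro on Compound 1

The source may hold more compounds than are shown below. What is called first, only, known or untested is meant among the compounds shown, and "the series" means these compounds.

Compound 1 `O=C1CC2(CO1)CSC(=S)N2c1ccc(F)cc1` was tested in a functional assay on MCF7 cells (Homo sapiens) for antiproliferative activity, read by MTT assay, with a stated time of 72 h; a lower number here means a stronger inhibitor, a higher number a weaker inhibitor. In this assay compound 1 gives > 50 ug/mL, which is a limit of the assay and not a number. Compound 2 `CN(C)C(=S)SCC1=CCOC1=O` shares only part of its makeup with compound 1. In this assay compound 2 gives > 50 ug/mL, again a limit rather than a number. Both readings sit at the limit of > 50 ug/mL in this assay, at which 2 of the 2 values shown sit, so neither compound reaches a strength the assay can put a number on, and no order between the two can be drawn.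

Compound 3 `O=C1CC2(CO1)CSC(=S)N2c1ccc(Cl)cc1` differs from compound 1 by chloro in place of fluoro on an aromatic carbon, para to a large group. Within the data shown here, no measured pair in this set shows what such a swap does, so any step is an expectation rather than a reading. Because compound 1 sits at the limit of > 50 ug/mL in this assay, at which 2 of the 2 values shown sit, the most likely outcome is that compound 3 also falls at or near that limit. Compound 3 is expected to give 60 ug/mL, with a range from 20 ug/mL to 200 ug/mL. The expected step that the limit leaves unreadable from compound 1 to compound 3 is none beyond the scatter.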

Compound 3, half-maximal inhibitory concentration: > 50 ug/mL
Compound 3: only a limit was reported; the forecaster's own chance of this, stated with the estimate: 75%; the middle value lies beyond the limit too.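

No step can be read between compound 1 and compound 3, since chloro in place of fluoro leaves both compounds with a limit of the assay rather than a number: the limit of > 50 ug/mL in this assay, at which 3 of the 3 values shown sit.

The compounds shown leave open how strong any of them really is in this assay, and whether fluoro and chloro differ there at all.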